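Methoxy for Nitro on the Benzylsulfanyl Chain

This account rests on a few compounds, and the source may have more. Where it says the series, first, only, none or still open, it means among the compounds named here.

Three measured compounds share one core. Compound 1 `Cc1cc(N2CC[C@@H](C)[C@@H](N(C)c3ncnc4[nH]ccc34)C2)n2nc(SCC3CC3)nc2n1` gives 27900 nM in a toxicity assay on GES1 cells (Homo sapiens) for inhibition, read by MTT assay, with a stated time of 72 h; on this read-out lower numbers stand for stronger inhibition and higher numbers for weaker inhibition. Compound 2 `C=CCSc1nc2nc(C)cc(N3CC[C@@H](C)[C@@H](N(C)c4ncnc5[nH]ccc45)C3)n2n1` reaches only > 100000 nM in this assay, which is a limit of the assay and not a number. Compound 3 `Cc1cc(N2CC[C@@H](C)[C@@H](N(C)c3ncnc4[nH]ccc34)C2)n2nc(SCc3ccc([N+](=O)[O-])cc3)nc2n1` gives 36600 nM in this assay; among the two numbers it stands highest, with compound 1 nearest and within the scatter. The measured steps read an at least 3.5-fold higher number from compound 1 to compound 2 (0.55 log units; beyond the scatter), a 1.3-fold higher number from compound 1 to compound 3 (0.12 log units; within the scatter) and an at least 2.7-fold lower number from compound 2 to compound 3 (0.43 log units; beyond the scatter). Compound 4 `COc1ccc(CSc2nc3nc(C)cc(N4CC[C@@H](C)[C@@H](N(C)c5ncnc6[nH]ccc56)C4)n3n2)cc1` differs from compound 3 by methoxy in place of nitro on an aromatic carbon. Because a 1.3-fold higher number from compound 1 to compound 3 (0.12 log units; within the scatter), he expects a 1.0-fold lower number from compound 3 to compound 4 (0.02 log units; within the scatter), a step not beyond the scatter. Compound 4 is therefore estimated at 35000 nM, between 15000 nM and 90000 nM.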

Compound 4, half-maximal inhibitory concentration: > 100000 nM
Compound 4: only a limit was reported; the forecaster's own chance of this, stated with the estimate: 20%; at least 2.8-fold (0.45 log units) between middle value and limit.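

Methoxy in place of nitro on the aromatic carbon gives an at least 2.7-fold higher number from compound 3 to compound 4 (0.43 log units; beyond the scatter) in this assay, so this carbon matters in a way that the chain change from compound 1 to compound 3 did not suggest. The 4-methoxyphenyl group in place of cyclopropyl likewise gives an at least 3.5-fold higher number from compound 1 to compound 4 (0.55 log units; beyond the scatter). Compound 4 stands at a limit of the assay and not a number, as does compound 2, and the step between them cannot be read: the limit of > 100000 nM in this assay, at which 2 of the 4 values shown sit.

On these data alone, whether an amine or a hydroxyl on that aromatic carbon would give a number in this assay stays open. As far as these compounds go, how far compound 4 lies past its limit also stays open.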